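Sulfone substituent swap on the piperidine sulfonamide series

The compounds below may be only part of what the source reports. "The series", "measured", "known", "first", "only" and "open" are said of these compounds alone.

Compound 1 `O=C([C@@H]1CCCN(S(=O)(=O)c2ccc(S(=O)(=O)C3CCC3)cc2)C1)N1CCC(F)(F)CC1` carries a cyclobutylsulfonyl group on the aryl ring and a difluoropiperidine amide. For the measured compounds named here, in a functional assay on MIA PaCa-2 cells (Homo sapiens) for inhibition, read by MTT assay, with a stated time of 7 days (on this read-out lower numbers stand for stronger inhibition and higher numbers for weaker inhibition), compound 1 gives 9 nM, the lowest of the two numbers measured so far. Compound 2 `CCN(CC)S(=O)(=O)c1ccc(S(=O)(=O)N2CCC[C@@H](C(=O)N[C@@H]3CCOC3)C2)cc1` differs from compound 1 in several places at once, and in this assay compound 2 gives 750 nM, a number far beyond the scatter from that of compound 1; with more than one change between them, no single part of the structure can be credited.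

Compound 3 `CC(C)CS(=O)(=O)c1ccc(S(=O)(=O)N2CCC[C@@H](C(=O)N3CCC(F)(F)CC3)C2)cc1` is the direct analogue of compound 1 with isobutyl in place of cyclobutyl on a sulfonyl sulfur. Going by the values given here, no measured pair shows this change alone. Both groups are four-carbon alkyl substituents on the same sulfonyl sulfur, so the step from compound 1 to compound 3 is expected to stay within the scatter, a 1.3-fold higher number from compound 1 to compound 3 (0.12 log units; within the scatter). For compound 3 in this assay the expected value is 12 nM, with a range from 4 nM to 40 nM.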

Compound 3, half-maximal inhibitory concentration: 80 nM
Beside the measured number, compound 3's estimate is 6.7-fold (0.82 log units) below it, and the stated range ends below it.
By their numbers in this assay, from the lowest: compound 1; then compound 3; then compound 2.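

On a sulfonyl sulfur, isobutyl in place of cyclobutyl gives the series its first comparison at a single place: in this assay the result is an 8.9-fold higher number from compound 1 to compound 3 (0.95 log units; beyond the scatter). Both groups count 4 heavy atoms, all carbon, so at this position the count alone does not settle the number; the computed difference is the four-membered ring, present in cyclobutyl and absent in isobutyl. Nothing at hand accounts for the step.

On these data alone, whether the ring or the particular chain shape goes with the number remains open; a cyclopentyl group or an unbranched butyl chain on the same sulfur would separate the two. This single pair also leaves open whether the step carries over to other amides, such as the morpholine amide, in place of the difluoropiperidine amide.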